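Replacing the amide group of compound 3 with 4-chlorobenzyl

This account rests on a few compounds, and the source may have more. Where it says the series, first, only, none or still open, it means among the compounds named here.

compound 1 `N[C@H]1CC[C@H](Nc2c(C(=O)NCc3ccco3)nc(Br)c3cccnc23)CC1`: 10000 nM
compound 2 `N[C@H]1CC[C@H](Nc2c(C(=O)NCc3ccc(Cl)cc3Cl)nc(Br)c3cccnc23)CC1`: 6000 nM
compound 3 `C[C@H](NC(=O)c1nc(Br)c2cccnc2c1N[C@H]1CC[C@H](N)CC1)c1ccc(F)cc1`: 9000 nM

All three values come from a functional assay on SK-BR-3 cells (Homo sapiens) for cytotoxicity, read by MTT assay, with a stated time of 72 h; on this read-out lower numbers stand for stronger inhibition and higher numbers for weaker inhibition. Compound 3, at 9000 nM, cannot be separated from the other two: the data show a 1.1-fold lower number from compound 1 to compound 3 (0.05 log units; within the scatter) and a 1.5-fold higher number from compound 2 to compound 3 (0.18 log units; within the scatter).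

The compound still to be measured is compound 4 `N[C@H]1CC[C@H](Nc2c(C(=O)NCc3ccc(Cl)cc3)nc(Br)c3cccnc23)CC1`. Its difference from compound 3 is this: 4-chlorobenzyl in place of 1-(4-fluorophenyl)ethyl on an amide-type nitrogen. Put simply, 4-chlorobenzyl takes the place of 1-(4-fluorophenyl)ethyl on an amide-type nitrogen, while the shared core stays the same.

Within the data shown here, the steps that bear on this change are the two above and a 1.7-fold lower number from compound 1 to compound 2 (0.22 log units; within the scatter). All three are swaps on that same nitrogen, and all three stay within the scatter. The nearest relative of the new group is the 2,4-dichlorobenzyl of compound 2, at 6000 nM. No step beyond the scatter is therefore expected, and the estimate is a 1.3-fold lower number from compound 3 to compound 4 (0.11 log units; within the scatter). Compound 4 is expected at about 7000 nM, with an estimated range of 3500 nM to 14000 nM.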

Compound 4, half-maximal inhibitory concentration: 2000 nM
Compound 4: the middle estimate sits 3.5-fold (0.54 log units) above what was measured, outside the stated range (below it).
By their numbers in this assay, from the lowest: compound 4; then compounds 2, 3 and 1 (each within the scatter of the next).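

In this assay, this amide nitrogen now proves sensitive to what it carries: the earlier swaps all stayed within the scatter, whereas 4-chlorobenzyl gives steps beyond it in place of 1-(4-fluorophenyl)ethyl (a 4.5-fold lower number from compound 3 to compound 4 (0.65 log units; beyond the scatter)) and in place of (furan-2-yl)methyl (a 5.0-fold lower number from compound 1 to compound 4 (0.70 log units; beyond the scatter)). Even a small edit of the group counts, as hydrogen in place of chloro on an aromatic carbon also gives a step beyond the scatter (a 3.0-fold lower number from compound 2 to compound 4 (0.48 log units; beyond the scatter)), so the two chlorinated benzyl groups do not behave alike. Nothing shown here gives the reason for these steps.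

Going by these compounds, the swap of 1-(4-fluorophenyl)ethyl for 4-chlorobenzyl changes both the halogen and the branching methyl at once, so the share of each stays open. A 4-fluorobenzyl or plain benzyl group on the same nitrogen would begin to separate them.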